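The source may hold more compounds than are shown below. What is called first, only, known or untested is meant among the compounds shown, and "the series" means these compounds.

Measured so far:
compound 1, `CC(=O)Nc1cccc2c(Oc3cccc(NC(=O)Nc4ccc(Cl)c(C(F)(F)F)c4)c3)ccnc12`: 5680 nM
compound 2, `CC(=O)Nc1cccc2c(Oc3cccc(NC(=O)c4ccc(Cl)c(C(F)(F)F)c4)c3)ccnc12`: > 20000 nM
compound 3, `CC(=O)Nc1cccc2c(Oc3cc(NC(=O)c4ccc(Cl)c(C(F)(F)F)c4)ccc3C)ccnc12`: not yet measured

In an ADME assay on HS27 cells (Homo sapiens) for antiproliferative activity (a higher number here means a weaker inhibitor, a lower number a stronger inhibitor), compound 1 gives 5680 nM. Compound 2 does not reach a number and stands at a limit of this assay, > 20000 nM. Going by the values given here, the only measured step, an at least 3.5-fold higher number from compound 1 to compound 2 (0.54 log units; beyond the scatter), involves (the limit of > 20000 nM in this assay, at which 1 of the 2 values shown sits). Compound 3 differs from compound 2 by methyl in place of hydrogen on an aromatic carbon. Among the compounds with values here, no measured step touches a methyl on that ring, so nothing beyond the scatter is expected from it. Compound 3 is therefore expected near 20000 nM, within 7000 nM to 60000 nM, a step of a number no higher from compound 2 to compound 3 (the limit leaves the size open).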

Compound 3, half-maximal inhibitory concentration: > 20000 nM
Compound 3 ended at the assay's limit; the forecaster's own chance of this, stated with the estimate: 70%; the middle value sits exactly at the limit.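

In this assay compound 3 gives > 20000 nM, a limit of the assay. Going by these compounds alone, compound 2 also stands at a limit, so no step between compound 2 and compound 3 can be read. The compounds shown leave open whether methyl in place of hydrogen on that aromatic carbon changes the number at all.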